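This account rests on a few compounds, and the source may have more. Where it says the series, first, only, none or still open, it means among the compounds named here.

Working notes on the series, all read in a functional assay on SGC-7901 cells (Homo sapiens) for antiproliferative activity, read by MTT assay, with a stated time of 72 h (a lower number here means a stronger inhibitor, a higher number a weaker inhibitor), throughout. Compound 1 (`COc1ccc(-c2ssc(=S)c2-c2cc(OC)c(OC)c(OC)c2)cc1[N+](=O)[O-]`) gives 13600 nM in this read-out. Compound 2 (`COc1ccc(-c2ss/c(=N/O)c2-c2cc(OC)c(OC)c(OC)c2)cc1`) gives 17400 nM and so lies within the scatter of compound 1. Compound 3 (`COc1ccc(-c2c(-c3cc(OC)c(OC)c(OC)c3)ss/c2=N/O)cc1`) stands at > 100000 nM as a limit of the assay and not a number. The count so far is the limit of > 100000 nM in this assay, at which 1 of the 3 values shown sits, and no more than that.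

Compound 4 (`COc1ccc(-c2c(-c3cc(OC)c(OC)c(OC)c3)ss/c2=N/O)cc1N`) comes from compound 3 by one change, from 4-methoxyphenyl to 3-amino-4-methoxyphenyl: amino in place of hydrogen on an aromatic carbon, ortho to a methoxy group (amino in place of hydrogen on an aromatic carbon). Among the compounds with values here, no measured pair isolates this change, so its size cannot be read from the data. Within the data shown here, the only numerical anchors are compound 1 at 13600 nM and compound 2 at 17400 nM in the same assay, and the expectation leans on them. A shift toward a stronger inhibitor, beyond the scatter, is expected, with wide uncertainty. The expected change, an at least 16-fold lower number from compound 3 to compound 4 (1.22 log units; beyond the scatter) as estimated, starts from a limit and not from a number. The estimate for compound 4 is 6000 nM with an expected range from 300 nM to 60000 nM in this assay.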

Compound 4, half-maximal inhibitory concentration: 2910 nM
Estimate against measurement, compound 4: 2.1-fold (0.31 log units) above, within the range that was stated.
By their numbers in this assay, from the lowest: compound 4; then compounds 1 and 2 (each within the scatter of the next). At a limit, above all of these: compound 3.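

In this assay, within the data shown here, amino in place of hydrogen on an aromatic carbon, ortho to a methoxy group, gives an at least 34-fold lower number from compound 3 to compound 4 (1.53 log units; beyond the scatter), and this is the first pair that isolates a single change at this position. Compound 3 stands at a limit of the assay and not at a number, so the step gives only a lower bound on the size of the change: the limit of > 100000 nM in this assay, at which 1 of the 4 values shown sits. Even so, the position on the 4-methoxyphenyl group is now shown to matter, as this one added amino is enough to bring the read-out from a limit to a measured value, something no earlier pair could show.

As far as these compounds go, it remains open whether this shift is specific to the amino or would also follow from another group on the same carbon, such as a hydroxyl, a methylamino, an acetamide or a fluorine. From the compounds shown here alone, it also remains open whether the same change would carry over to the core of compound 2, which holds a measured value and so could give a step of known size.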